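Dimethylamino in place of isopropylamino on the shared core

The source may report more compounds than this note shows. Statements on the series, on what has been measured and on what is new or still open speak of the compounds shown alone.

Of the compounds shown here, three sharing one core have been measured in a functional assay on the whole organism with Rattus norvegicus as the target, at a dose of 40 mg/kg by the intraperitoneal route; on this read-out lower numbers stand for less inhibition and higher numbers for more inhibition at the one dose given (going by the name of the read-out). Compound 1 `Cc1nc2c(OCc3ccccc3)cccn2c1NC=O` gives 49%, compound 2 `CNc1c(C)nc2c(OCc3ccccc3)cccn12` gives 55%, and compound 3 `Cc1nc2c(OCc3ccccc3)cccn2c1NC(C)C` gives 18%. Compound 3 stands lowest of the three numbers: the nearest is compound 1, and the furthest is compound 2. Moving from compound 1 to compound 2, a number 6 percentage points higher from compound 1 to compound 2 (within the scatter). Moving from compound 1 to compound 3, a number 31 percentage points lower from compound 1 to compound 3 (beyond the scatter), and from compound 2 to compound 3, a number 37 percentage points lower from compound 2 to compound 3 (beyond the scatter).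

Compound 4 `Cc1nc2c(OCc3ccccc3)cccn2c1N(C)C` differs from compound 3 in one place: dimethylamino in place of isopropylamino on an aromatic carbon. Among the compounds with values here, the steps that bear on this change are the two leading into compound 3, both large drops from the smaller formyl and methyl groups to the isopropyl group. Within the data shown here, the dimethylamino group carries fewer heavy atoms than the isopropylamino group it replaces, yet it is not one of the groups already measured, and no measured step shows what losing the hydrogen-bond donor does. A partial recovery toward the numbers of compound 1 and compound 2 therefore seems plausible, though with wide uncertainty.

For compound 4 the expected result in this assay is 32%, with a range from 10% to 55%; this estimate means a number 14 percentage points higher from compound 3 to compound 4 (beyond the scatter).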

Compound 4, a percentage reported as inhibition, in the whole organism at one dose (the size of the read-out at that dose, not a potency): 76%
For compound 4 the middle estimate is 44 percentage points below the measured one; measured number above the stated range.
By their numbers in this assay, from the lowest: compound 3; then compounds 1 and 2 (each within the scatter of the next); then compound 4.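

Until now, this assay had suggested that the bulkier isopropylamino group went with a low number, but compound 4 shows that more than one carbon group on this nitrogen does not by itself bring the number down: dimethylamino in place of isopropylamino gives a number 58 percentage points higher from compound 3 to compound 4 (beyond the scatter). Methyl in place of the hydrogen on the nitrogen gives a number 21 percentage points higher from compound 2 to compound 4 (beyond the scatter), and dimethylamino in place of formylamino gives a number 27 percentage points higher from compound 1 to compound 4 (beyond the scatter), so compound 4 now stands highest of the four and the numbers at this position are not capped at the level of compound 1 and compound 2. No independent measurement is available to explain this rise.

The compounds shown leave open whether the high number depends on two methyl groups in particular or would hold for larger groups, as a diethylamino group would test, or for a ring that ties both carbons together, as in pyrrolidine. On these data alone, they also cover a single dose in one read-out, so how compound 4 would behave across a range of doses remains unknown.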